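Swapping the side group of compound 1 for hydroxymethyl

The source may report more compounds than this note shows. Statements on the series, on what has been measured and on what is new or still open speak of the compounds shown alone.

Compound 1 `CC/N=C(\S)[C@]1(c2cccnc2)CCCC[S+]1[O-]`: 300 nM
Compound 2 `[O-][S+]1CCCC[C@]1(/C(S)=N/c1ccccc1)c1cccnc1`: > 30000 nM (a limit)

Within the data shown here, in a functional assay (aorta) for inhibition, with Rattus norvegicus as the target (a higher number here means a weaker inhibitor, a lower number a stronger inhibitor), compound 1 gives 300 nM, the only true number so far. Compound 2 stands at > 30000 nM, which is a limit of the assay and not a number. That limit is described as the limit of > 30000 nM in this assay, at which 1 of the 2 values shown sits.

Compound 3 `[O-][S+]1CCCC[C@]1(CO)c1cccnc1` replaces the whole side group of compound 1: a group of 2 heavy atoms (1 carbon, 1 oxygen; no ring) in place of a group of 5 heavy atoms (3 carbon, 1 nitrogen, 1 sulfur; no ring), on a saturated ring carbon. Among the measured compounds shown here, one measured step bears on this group, a large one: an at least 100-fold higher number from compound 1 to compound 2 (2.00 log units; beyond the scatter). A large change in this assay is therefore expected, towards a weaker inhibitor. The expected step is a 50-fold higher number from compound 1 to compound 3 (1.70 log units; beyond the scatter). For compound 3 the estimate is 15000 nM, with an expected range of 2000 nM to 60000 nM.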

Compound 3, concentration for 90% inhibition: > 30000 nM
Compound 3: only a limit was reported; the forecaster's own chance of this, stated with the estimate: 60%; middle value at least 2.0-fold (0.30 log units) away from the limit.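

In this assay, hydroxymethyl on this saturated ring carbon gives an at least 100-fold higher number from compound 1 to compound 3 (2.00 log units; beyond the scatter), so replacing the whole side group, and not only the group on its double-bonded nitrogen, can cost this much. The value of compound 3 is a limit of the assay and not a number. Compound 1 remains the only compound with a true number, and the other two sit at a shared limit: the limit of > 30000 nM in this assay, at which 2 of the 3 values shown sit.

On these data alone, the true size of both losses stays unknown. Also open, as far as these compounds go, is whether a propyl group on that nitrogen, or an aminomethyl group on the ring carbon, would give a true number.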